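Swapping the aryl group on a thiosemicarbazone hydroxyurea

The source may report more compounds than this note shows. Statements on the series, on what has been measured and on what is new or still open speak of the compounds shown alone.

Of the compounds shown here, two have been tested in a functional assay on NCI-H460 cells (Homo sapiens) for cytotoxicity, read by MTT assay, with a stated time of 48 h; on this read-out lower numbers stand for stronger inhibition of growth and higher numbers for weaker inhibition of growth. Compound 1, `O=C1Nc2ccccc2/C1=N/NC(=S)N1CCN(C(=O)NO)CC1`, returns only a limit of the assay in this assay, > 100000 nM, which is the case described by the limit of > 100000 nM in this assay, at which 1 of the 2 values shown sits. Among the compounds with values here, compound 2, `O=C(NO)N1CCN(C(=S)N/N=C/c2ccccc2O)CC1`, is the one compound with a number: in this assay compound 2 gives 5150 nM, and it stands alone as the only measured concentration. Compound 3, `O=C(NO)N1CCN(C(=S)N/N=C/c2ccc(Cl)cc2)CC1`, differs from compound 2 by a single exchange on the aryl side: 4-chlorophenyl in place of 2-hydroxyphenyl on a carbon with a double bond to nitrogen. Within the data shown here, since no step between two measured compounds exists in this set, there is nothing to calibrate how such an exchange moves the read-out. The expectation is therefore held close to compound 2, with a modest shift towards weaker inhibition expressed by the estimated step of a 1.7-fold higher number from compound 2 to compound 3 (0.24 log units; within the scatter), which lies near the scatter of repeated measurements. Compound 3 is accordingly estimated at 9000 nM in this assay, within an expected range from 2500 nM to 40000 nM.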

Compound 3, concentration for 50% growth inhibition: 16000 nM
Estimate against measurement, compound 3: 1.8-fold (0.25 log units) below; the range from low to high includes it.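

Within the data shown here, the exchange of 2-hydroxyphenyl for 4-chlorophenyl on a carbon with a double bond to nitrogen gives, in this assay, a 3.1-fold higher number from compound 2 to compound 3 (0.49 log units; beyond the scatter), the first step that can be read between two measured compounds. It shows that the read-out at this position responds to the choice of aryl group, with growth inhibition weaker after the exchange. It also shows that a number survives the change: the group that enters carries no hydrogen-bond donor or acceptor, yet compound 3 still gives a measured concentration and not a limit. No measurement shown here bears on why the step has this size.

The exchange removes the hydroxyl group and brings in the chlorine in one move, and it also changes where the substituent stands, so phenyl without a substituent, 2-chlorophenyl or 4-hydroxyphenyl would be needed to take these parts apart. Going by these compounds, how an amine or a carboxylic acid on the aryl ring would behave at this position remains open, as does any wider trend across aryl groups, which a single step cannot establish.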